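The source may report more compounds than this note shows. Statements on the series, on what has been measured and on what is new or still open speak of the compounds shown alone.

Measured so far in a functional assay on DU-145 cells (Homo sapiens) for inhibition, read by trypan blue exclusion, with a stated time of 96 h; on this read-out higher numbers stand for weaker inhibition of growth and lower numbers for stronger inhibition of growth:
compound 1 `COc1ccc(S/C(=C/c2ccc(Cl)cc2Cl)C(=O)c2ccc(Br)cc2)cc1` gives 1000 nM
compound 2 `O=C(/C(=C\c1ccc(Br)cc1)S(=O)(=O)c1ccc(Br)cc1)c1ccc(Br)cc1` gives 10000 nM
compound 3 `COc1ccc(S/C(=C/c2ccc(Br)cc2)C(=O)c2ccc(Br)cc2)cc1` gives 20000 nM

Compound 3 and compound 2 share no counted difference: the difference between their two cores is not broken down here, and their two numbers in this assay sit within the scatter of each other.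

One change is seen once in measured compounds. From compound 3 to compound 1 it is 2,4-dichlorophenyl in place of 4-bromophenyl on a double-bonded chain carbon bound to a double-bonded chain carbon, and it made the step of a 20-fold lower number from compound 3 to compound 1 (1.30 log units; beyond the scatter). Compound 4 `O=C(/C(=C\c1ccc(Cl)cc1Cl)S(=O)(=O)c1ccc(Br)cc1)c1ccc(Br)cc1` is not yet measured; it differs from compound 2 by 2,4-dichlorophenyl in place of 4-bromophenyl on a double-bonded chain carbon bound to a double-bonded chain carbon, the same change.

Among the compounds with values here, for compound 4 the expected step is a 14-fold lower number from compound 2 to compound 4 (1.15 log units; beyond the scatter), resting only on the single earlier step of a 20-fold lower number from compound 3 to compound 1 (1.30 log units; beyond the scatter) applied to the number of compound 2, 10000 nM. Compound 4 is therefore estimated at 700 nM in this assay, within 150 nM to 3000 nM.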

Compound 4, concentration for 50% growth inhibition: 10000 nM
Compound 4: the middle estimate sits 14-fold (1.15 log units) below what was measured; measured number outside the range, above it.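

In this assay, 2,4-dichlorophenyl in place of 4-bromophenyl gives no change at the digits printed from compound 2 to compound 4 (within the scatter), so the large step seen on the core of compound 3 does not carry over to the core of compound 2: the same change on two cores in this assay, a 20-fold lower number (1.30 log units; beyond the scatter) from compound 3 to compound 1 and no change at the digits printed (within the scatter) from compound 2 to compound 4, 20-fold (1.30 log units) apart, beyond the scatter of two such steps

In these two pairs the size of the step depends on the core, and a step read on one core is no guide to the other. This does not show which feature of the cores sets the gap, and two pairs give no rule for the wider series.

The compounds shown do not break down the difference between the two cores, so the part of it that matters stays open. Also open, on these data alone, is how each core responds to an amine or a carboxylic acid in place of the 4-bromophenyl.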